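An isopropyl to cyclopropyl swap on the strongest inhibitor

The source may hold more compounds than are shown below. What is called first, only, known or untested is meant among the compounds shown, and "the series" means these compounds.

In a functional assay (aorta) with Rattus norvegicus as the target (a lower number here means a stronger inhibitor, a higher number a weaker inhibitor), compound 1 `COc1ccc(CN(C)CCCOc2ccc(S(=O)(=O)c3c(C(C)C)cn4ccccc34)cc2)cc1OC` gives 3.18 nM and stands lowest of the three measured numbers, which makes it the strongest inhibitor among them. Compound 2 `COc1ccc(CNCCCOc2ccc(S(=O)(=O)c3c(C(C)C)cn4ccccc34)cc2)cc1OC` gives 13 nM and compound 3 `CC(C)c1cn2ccccc2c1S(=O)(=O)c1ccc(OCCCN(C)C)cc1` gives 390 nM in the same read-out. Hydrogen in place of methyl on the amine nitrogen gives a modest step (a 4.1-fold higher number from compound 1 to compound 2 (0.61 log units; beyond the scatter)), while loss of the 3,4-dimethoxyphenyl group gives large ones (a 120-fold higher number from compound 1 to compound 3 (2.09 log units; beyond the scatter)) and (a 30-fold higher number from compound 2 to compound 3 (1.48 log units; beyond the scatter)).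

Compound 4 `COc1ccc(CN(C)CCCOc2ccc(S(=O)(=O)c3c(C4CC4)cn4ccccc34)cc2)cc1OC` differs from compound 1 at another place (cyclopropyl in place of isopropyl on an aromatic carbon): cyclopropyl in place of isopropyl on an aromatic carbon. All three measured steps lie on the amine side of the molecule, so none of them tests this place and none gives a size for this change. The data therefore hold no direct evidence, and no step beyond the scatter is expected for so small an exchange. The expected step in this assay is small and slightly upward (a 1.6-fold higher number from compound 1 to compound 4 (0.20 log units; within the scatter)). The estimate for compound 4 is 5 nM (expected range 1.5 nM to 20 nM).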

Compound 4, half-maximal inhibitory concentration: 4.7 nM
Estimate against measurement, compound 4: 1.1-fold (0.03 log units) above, and the stated range covers the measured number.
By their numbers in this assay, from the lowest: compounds 1 and 4 (each within the scatter of the next); then compound 2; then compound 3.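

In this assay, among these compounds, cyclopropyl in place of isopropyl on this aromatic carbon gives a 1.5-fold higher number from compound 1 to compound 4 (0.17 log units; within the scatter), which supplies the first measured step at a place that all the earlier steps, confined to the amine side of the molecule, left untested. The two groups have the same count of heavy atoms, and the one three-membered non-aromatic ring that enters with cyclopropyl leaves compound 4 within the scatter of compound 1, so this assay does not tell the two groups apart at this position. No measurement of any property accompanies this result, so the data offer no explanation for it.

The compounds shown hold only these two groups at this position, so it remains open how a hydrogen, a tert-butyl group, a phenyl ring or a longer chain such as n-butyl would read in this assay. As far as these compounds go, it also remains open whether the same exchange would give a step of similar size with the hydrogen on the amine nitrogen of compound 2 or with the dimethylamino group of compound 3.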